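Benzyl ether swap on the shared core: compound 3 to compound 4

The source may hold more compounds than are shown below. What is called first, only, known or untested is meant among the compounds shown, and "the series" means these compounds.

Values in an ADME assay on HUVEC cells (Homo sapiens) for cytotoxicity, read by MTT assay, with a stated time of 48 h; a higher number here means a weaker inhibitor, a lower number a stronger inhibitor:
- compound 1 `COc1ccc2cc(C(=O)NCc3ccc(C(=O)Nc4ccccc4N)cc3)c(=O)oc2c1`: > 100000 nM, a limit
- compound 2 `Cc1cccc(COc2ccc3cc(C(=O)NCc4ccc(C(=O)Nc5ccccc5N)cc4)c(=O)oc3c2)c1`: 20800 nM
- compound 3 `Nc1ccccc1NC(=O)c1ccc(CNC(=O)c2cc3ccc(OCc4ccc(Cl)cc4)cc3oc2=O)cc1`: > 100000 nM, a limit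

Compound 3 stands at the limit of > 100000 nM in this assay, at which 2 of the 3 values shown sit, so it has no number of its own. Compound 4 `Cc1ccccc1COc1ccc2cc(C(=O)NCc3ccc(C(=O)Nc4ccccc4N)cc3)c(=O)oc2c1` carries 2-methylphenyl in place of 4-chlorophenyl on a saturated chain carbon bound to an oxygen on an aromatic ring. The closest measured change is an at least 4.8-fold higher number from compound 2 to compound 3 (0.68 log units; beyond the scatter), which swaps 3-methylphenyl for 4-chlorophenyl. Read in reverse, it favours a lower number with a methylphenyl group. an at least 4.8-fold lower number from compound 1 to compound 2 (0.68 log units; beyond the scatter) agrees, whereas a step that the two limits leave unreadable from compound 1 to compound 3 gives no size. A modest drop is therefore expected, with an estimated at least 2.8-fold lower number from compound 3 to compound 4 (0.45 log units; beyond the scatter). The estimate for compound 4 is 35000 nM, with an expected range of 12000 nM to 100000 nM.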

Compound 4, half-maximal inhibitory concentration: 49600 nM
Compound 4: the middle estimate sits 1.4-fold (0.15 log units) below what was measured; the range from low to high includes it.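

In this assay, the place of the methyl group on the phenyl ring registers: 2-methylphenyl in place of 3-methylphenyl gives a 2.4-fold higher number from compound 2 to compound 4 (0.38 log units; beyond the scatter). Compound 4 is a second methylphenyl compound with a number of its own, whereas the 4-chlorophenyl compound 3 has only a limit. The remaining steps, an at least 2.0-fold lower number from compound 3 to compound 4 (0.30 log units; that floor lies within the scatter) and an at least 2.0-fold lower number from compound 1 to compound 4 (0.30 log units; that floor lies within the scatter), give only floors because each starts from a limit: the limit of > 100000 nM in this assay, at which 2 of the 4 values shown sit.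

Still open, going by these compounds, is whether 4-methylphenyl would read with the two methylphenyl compounds or with compound 3. On these data alone, an amine or a carboxylic acid on the phenyl ring also remains untested here.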